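Two dimethylaminoethyl arms in place of the piperidinylpropyl chain

This account rests on a few compounds, and the source may have more. Where it says the series, first, only, none or still open, it means among the compounds named here.

Compound 3 `CN(CCCN1CCCCC1)c1cccc(C(=O)N2CCc3ccc(OS(N)(=O)=O)cc3C2)c1` gives 24.1% in an assay on HEK293 cells for inhibition of Steryl-sulfatase (Homo sapiens), tested at 0.1 uM (on this read-out higher numbers stand for a stronger effect at the one concentration tested and lower numbers for a weaker effect), the second highest of three numbers. Its nearest neighbour is compound 1 `CCN(Cc1ccncc1)c1cccc(C(=O)N2CCc3ccc(OS(N)(=O)=O)cc3C2)c1` with 33.3%, and the step of a number 9.2 percentage points lower from compound 1 to compound 3 (within the scatter) lies within the scatter. Compound 2 `CN(C)CCN(Cc1ccccc1)c1cccc(C(=O)N2CCc3ccc(OS(N)(=O)=O)cc3C2)c1` gives 0%, a value beyond the scatter from that of compound 3. Compound 4 `CN(C)CCN(CCN(C)C)c1cccc(C(=O)N2CCc3ccc(OS(N)(=O)=O)cc3C2)c1` has not yet been measured; it differs from compound 3 as follows: bis(2-(dimethylamino)ethyl)amino in place of methyl(3-(piperidin-1-yl)propyl)amino on an aromatic carbon. Within the data shown here, the one measured step, from compound 1 to compound 3, was within the scatter, so it gives no direction for this change. Compound 2, which carries one 2-(dimethylamino)ethyl chain, gives the weakest reading seen, and compound 4 carries two such chains. Compound 4 is therefore expected to read lower, at 10% (range 0% to 25%), an estimated step of a number 14.1 percentage points lower from compound 3 to compound 4 (beyond the scatter).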

Compound 4, a percentage reported as inhibition, at one concentration (the size of the read-out at that concentration, not a potency): 0%
The estimate for compound 4 lay 10 percentage points above the measured number, and the stated range covers the measured number.
By their numbers in this assay, from the lowest: compounds 2 and 4 (each within the scatter of the next); then compounds 3 and 1 (each within the scatter of the next).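

In this assay, bis(2-(dimethylamino)ethyl)amino in place of methyl(3-(piperidin-1-yl)propyl)amino gives a number 24.1 percentage points lower from compound 3 to compound 4 (beyond the scatter), and in place of ethyl((pyridin-4-yl)methyl)amino it gives a number 33.3 percentage points lower from compound 1 to compound 4 (beyond the scatter), so at this aromatic carbon the reading depends on the identity of the group and not only on its heavy-atom count, which is shared by the first pair. With (dimethylamino)methyl in place of phenyl, the data show no change at the digits printed from compound 2 to compound 4 (within the scatter), placing both compounds with a 2-(dimethylamino)ethyl chain at the same printed reading whatever the second arm. No measurement here offers an explanation for these results. The compounds shown leave open whether a single 2-(dimethylamino)ethyl chain paired with a methyl arm would read like compound 3 or compound 4. Going by these compounds, how a morpholine or a carboxylic acid at the chain end would read also remains open.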